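The source may hold more compounds than are shown below. What is called first, only, known or untested is meant among the compounds shown, and "the series" means these compounds.

In an ADME assay on microsomes from liver (Rattus norvegicus) for metabolic stability, read by LC-MS, using NADPH, at 37 degrees C (a lower number here means that the compound disappears faster, a higher number that the compound lasts longer), compound 3 `Cc1oc(-c2c(Cl)cccc2Br)nc1CN1CCC(C(=O)NCCCN2C[C@H](C)C[C@H](C)C2)CC1` gives 0.0233 h, the lowest of the numbers in hand. Compound 1 `Cc1ccc(C)c(-c2nc(CN3CCC(C(=O)NCCCN4C[C@H](C)C[C@H](C)C4)CC3)c(C)o2)c1` gives 0.5 h. Compound 2 `Cc1cc(C)c(-c2nc(CN3CCC(C(=O)NCCCN4C[C@H](C)C[C@H](C)C4)CC3)c(C)o2)c(C)c1` reads > 0.5 h, which is a limit of the assay and not a number.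

Compound 4 `Cc1cccc(-c2nc(CN3CCC(C(=O)NCCCN4C[C@H](C)C[C@H](C)C4)CC3)c(C)o2)c1` differs from compound 3 in one place, on an aromatic carbon of a five-membered aromatic ring with 1 nitrogen and 1 oxygen, where 3-methylphenyl stands in place of 2-bromo-6-chlorophenyl: 3-methylphenyl in place of 2-bromo-6-chlorophenyl on an aromatic carbon. For the measured compounds named here, two measured steps bear on this change, a 21-fold lower number from compound 1 to compound 3 (1.33 log units; beyond the scatter) and an at least 21-fold lower number from compound 2 to compound 3 (1.33 log units; beyond the scatter). Both are large and beyond the scatter, and both end at the 2-bromo-6-chlorophenyl group. The third, a number no lower from compound 1 to compound 2 (the limit leaves the size open), leaves its size open.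

Compound 4 carries a methyl-bearing phenyl group, as compound 1 does, so going by a 21-fold lower number from compound 1 to compound 3 (1.33 log units; beyond the scatter) a large upward step is expected in this assay. The estimated change is an 11-fold higher number from compound 3 to compound 4 (1.03 log units; beyond the scatter). For compound 4 the expected half-life is 0.25 h, with an estimated range of 0.07 h to 0.6 h.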

Compound 4, half-life: > 0.5 h
Compound 4: only a limit was reported; the forecaster's own chance of this, stated with the estimate: 25%; middle value at least 2.0-fold (0.30 log units) from the limit.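

In this assay, compound 4 reads > 0.5 h, which is a limit of the assay and not a number. Even so, the change is readable in one direction: an at least 21-fold higher number from compound 3 to compound 4 (1.33 log units; beyond the scatter) shows that 3-methylphenyl on this aromatic carbon gives a large gain over 2-bromo-6-chlorophenyl, and among the four compounds shown, all three with a methyl-bearing phenyl group stand well clear of compound 3. The limit also gives a number no lower from compound 1 to compound 4 (the limit leaves the size open) for hydrogen in place of methyl on an aromatic carbon. The step that links compound 2 to compound 4 cannot be read, and no order among these three can be drawn from the limit: the limit of > 0.5 h in this assay, at which 2 of the 4 values shown sit.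

The compounds shown do not separate the bromine of compound 3 from its chlorine, so a phenyl group carrying chlorine alone or bromine alone remains an open case. From the compounds shown here alone, how an unsubstituted phenyl or a pyridine ring would read at this position also stays open.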